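Replacing the 4-Cyanophenyl Group of Compound 2

The source may report more compounds than this note shows. Statements on the series, on what has been measured and on what is new or still open speak of the compounds shown alone.

Of the compounds shown here, two have so far been measured in an in vitro assay on HEK385-7 cells for displacement of a labelled ligand from prostaglandin D2 receptor 2 (Homo sapiens); a lower number here means a stronger inhibitor, a higher number a weaker inhibitor. Compound 1 `O=C(O)Cc1sc(COc2ccc(Cl)cc2)nc1-c1ccc(Cl)cc1` gives 32 nM. Compound 2 `N#Cc1ccc(-c2nc(C(c3ccc(F)cc3)c3ccc(F)cc3)sc2CC(=O)O)cc1` gives 150 nM, the higher of the two numbers, so it is the weaker inhibitor of the pair, and its gap to compound 1 lies beyond the usual scatter of the measurement. Compound 3 `Cc1cc(-c2nc(C(c3ccc(F)cc3)c3ccc(F)cc3)sc2CC(=O)O)cnc1N` has not been measured yet. It differs from compound 2 in a single place: 6-amino-5-methylpyridin-3-yl in place of 4-cyanophenyl on an aromatic carbon. The 6-amino-5-methylpyridin-3-yl group thus takes the position of the 4-cyanophenyl group on the aromatic carbon next to the ring nitrogen. Within the data shown here, no measured pair shows this exact change, so there is no earlier step to lean on. The step of a 1.3-fold higher number from compound 2 to compound 3 (0.12 log units; within the scatter) is expected to be small, its direction uncertain and probably within or close to the scatter. Compound 3 is estimated at 200 nM, within a range from 50 nM to 800 nM.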

Compound 3, half-maximal inhibitory concentration: 880 nM
Beside the measured number, compound 3's estimate is 4.4-fold (0.64 log units) below it, outside the stated range (above it).
By their numbers in this assay, from the lowest: compound 1; then compound 2; then compound 3.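

In this assay, the aromatic carbon next to the ring nitrogen proves sensitive to which group it carries: 6-amino-5-methylpyridin-3-yl in place of 4-cyanophenyl gives a 5.9-fold higher number from compound 2 to compound 3 (0.77 log units; beyond the scatter), so compound 3 is the weaker inhibitor of this pair. Both groups hold 8 heavy atoms, so the step comes from a swap of equal heavy-atom count, but the nitrile leaves while a ring nitrogen, an amino group and a methyl group enter together, and this single step cannot separate them. Nothing measured here explains the loss.

Still open, on these data alone, is which of these three parts carries the step. A plain pyridin-3-yl group or a 4-aminophenyl group on the same carbon would begin to pull them apart.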